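A few compounds are considered here, and "the series" means these few. Any claim that something is new, unique, unknown or untested is made for them only; others in the source may bear on it.

Series notes on a functional assay on Bel-7402 cells (Homo sapiens) for cytotoxicity, read by sulforhodamine B assay; on this read-out higher numbers stand for weaker inhibition and lower numbers for stronger inhibition. Compound 1 `Oc1ccc(O)c(COCc2cc(O)cc(Cl)c2O)c1` gives 62300 nM, compound 2 `Oc1ccc(O)c(COCc2cc(O)ccc2O)c1` gives 57300 nM and compound 3 `OCc1cc(OCc2cc(O)ccc2O)cc(Cl)c1O` gives 38500 nM. Compound 3 holds the lowest of the three numbers, yet compound 2 and compound 1 both sit within the usual scatter of it, so no order among the three is claimed. The next compound, compound 4 `OCc1cc(OCc2cc(O)ccc2O)ccc1O`, differs from compound 3 in one place: hydrogen in place of chloro on an aromatic carbon. For the measured compounds named here, one measured step bears on this, the same change between compound 1 and compound 2, where a 1.1-fold lower number from compound 1 to compound 2 (0.04 log units; within the scatter) moved nothing beyond the scatter. The expected step in this assay is therefore a 1.1-fold lower number from compound 3 to compound 4 (0.03 log units; within the scatter), none beyond the scatter. Compound 4 is estimated at 36000 nM, with a range from 18000 nM to 72000 nM.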

Compound 4, half-maximal inhibitory concentration: 59000 nM
Beside the measured number, compound 4's estimate is 1.6-fold (0.21 log units) below it; measured number inside the range.
By their numbers in this assay, from the lowest: compounds 3, 2, 4 and 1 (each within the scatter of the next).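

On a second core, hydrogen in place of chloro on an aromatic carbon gives a 1.5-fold higher number from compound 3 to compound 4 (0.19 log units; within the scatter) in this assay. At this place, ortho to a hydroxy group and meta to a hydroxymethyl group, the chloro group therefore makes no difference that can be read beyond the scatter. The change now reads the same on both cores: the same change on two cores in this assay, a 1.1-fold lower number (0.04 log units; within the scatter) from compound 1 to compound 2 and a 1.5-fold higher number (0.19 log units; within the scatter) from compound 3 to compound 4, 1.7-fold (0.22 log units) apart, within the scatter of two such steps.

Only chloro and hydrogen are compared at this place. From the compounds shown here alone, whether an amine, a methoxy group or a carboxylic acid there would move the number beyond the scatter remains open.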